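Adding a Methyl to the Chain of Compound 3

This account rests on a few compounds, and the source may have more. Where it says the series, first, only, none or still open, it means among the compounds named here.

Compound 1, `CCC(C)C(NC(=O)n1nnc2ccccc21)C(=O)NC1CCCCC1`, gives 109000 nM in a functional assay on L1210 cells (Mus musculus) for inhibition; a higher number here means a weaker inhibitor, a lower number a stronger inhibitor.
Compound 2, `CCC(C)C(NC(=O)n1nnc2ccccc21)C(=O)NCc1ccccc1`, gives 123000 nM in this assay.
Compound 3, `CC(C)C(NC(=O)n1nnc2ccccc21)C(=O)NC1CCCC1`, gives > 200000 nM in this assay.

Compound 3 stands apart from the other two in that its result is a limit of the assay and not a number (the limit of > 200000 nM in this assay, at which 1 of the 3 values shown sits). Its position is therefore known only as lying beyond that limit.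

The unmeasured compound 4, `CCC(C)C(NC(=O)n1nnc2ccccc21)C(=O)NC1CCCC1`, differs from compound 3 by methyl in place of hydrogen on a saturated chain carbon, three bonds along the chain from an amide-type nitrogen and a carbonyl carbon. Going by the values given here, only one measured step exists, a 1.1-fold higher number from compound 1 to compound 2 (0.05 log units; within the scatter), and it concerns the group on the amide-type nitrogen, not the chain; no measured step covers the present change. What the numbers do show is where the sec-butyl chain sits: compound 1 carries it and gives 109000 nM, and compound 2 carries it and gives 123000 nM. Compound 4 carries the same chain with a cyclopentyl on the amide-type nitrogen, and is expected to land in that neighbourhood, which would mean a step of an at least 1.3-fold lower number from compound 3 to compound 4 (0.12 log units; that floor lies within the scatter) relative to the limit of compound 3. The estimate for compound 4 in this assay is 150000 nM, with a range from 70000 nM to 320000 nM.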

Compound 4, half-maximal inhibitory concentration: 102000 nM
Compound 4: middle estimate off by 1.5-fold (0.17 log units), on the high side; the measured number falls inside the stated range.
By their numbers in this assay, from the lowest: compounds 4, 1 and 2 (each within the scatter of the next). At a limit, above all of these: compound 3.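

Methyl in place of hydrogen on a saturated chain carbon, the change from isopropyl to sec-butyl, gives a number in this assay where there was none, the step being an at least 1.9-fold lower number from compound 3 to compound 4 (0.29 log units; that floor lies within the scatter) and its true size unknown. Compound 3 stands at a limit of the assay and not at a number: the limit of > 200000 nM in this assay, at which 1 of the 4 values shown sits. With the sec-butyl chain in place, cyclopentyl, benzyl and cyclohexyl on the amide-type nitrogen cannot be told apart (a 1.2-fold lower number from compound 2 to compound 4 (0.08 log units; within the scatter) and a 1.1-fold lower number from compound 1 to compound 4 (0.03 log units; within the scatter)).

Going by these compounds, how far compound 3 really lies from compound 4 stays open, so the effect of this methyl has only a floor. Also open, on these data alone, is whether a longer chain at this carbon, or an amine or a carboxylic acid on it, would move the number beyond the scatter.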